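The source may hold more compounds than are shown below. What is called first, only, known or untested is meant among the compounds shown, and "the series" means these compounds.

The measured compounds and their values in an ADME assay on J774 cells (Mus musculus) for cytotoxicity, read by MTT assay, with a stated time of 48 h, tested at 150 ug/mL; on this read-out lower numbers stand for a stronger effect and higher numbers for a weaker effect at the one concentration tested:
compound 1, `O=C(N/N=C/c1ccccc1)c1cnccn1`, gives 100%
compound 2, `O=C(N/N=C/c1ccc(Cl)cc1)c1cnccn1`, gives 56%
compound 3, `N#Cc1ccc(/C=N/NC(=O)c2cnccn2)cc1`, gives 100%

Compound 3 stands level with compound 1, and together the two hold the highest of the three numbers. The nearest to compound 3 is compound 1, no change at the digits printed from compound 1 to compound 3 (within the scatter). The furthest is compound 2, a number 44 percentage points higher from compound 2 to compound 3 (beyond the scatter).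

Compound 4, `CN(C)c1ccc(/C=N/NC(=O)c2cnccn2)cc1`, differs from compound 3 in one place: dimethylamino in place of cyano on an aromatic carbon

Among the compounds with values here, two measured steps touch this change, both ending at compound 3. The first, no change at the digits printed from compound 1 to compound 3 (within the scatter), shows that a cyano in place of hydrogen left the number where it was. The second, a number 44 percentage points higher from compound 2 to compound 3 (beyond the scatter), shows a large rise when a cyano stands in place of chloro. Within the data shown here, no measured step involves a dimethylamino, so the data give no direct reading for it. Hydrogen and cyano both reach the top value; only chloro, in compound 2 with 56%, pulls the number down. On this thin basis, the expectation for compound 4 is a number near the top, with room for a drop of the kind compound 2 shows.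

Compound 4 is therefore expected to give 90%, within a range from 55% to 100%. This estimate corresponds to an expected a number 10 percentage points lower from compound 3 to compound 4 (within the scatter), a step that may well stay within the scatter.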

Compound 4, a percentage reported as activity, at one concentration (the size of the read-out at that concentration, not a potency): 89%
Compound 4: the middle estimate sits 1 percentage points above what was measured, within the range that was stated.
By their numbers in this assay, from the lowest: compound 2; then compound 4; then compounds 1 and 3 (each within the scatter of the next).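

In this assay, dimethylamino on this aromatic carbon, para to a large group, brings a modest fall from the top level, seen as a number 11 percentage points lower from compound 3 to compound 4 (beyond the scatter) and as a number 11 percentage points lower from compound 1 to compound 4 (beyond the scatter) here. Among the groups shown, it is the first besides chloro to move the number beyond the scatter, yet it stays well clear of chloro, with a number 33 percentage points higher from compound 2 to compound 4 (beyond the scatter) in this comparison, so the position now separates three levels instead of two: hydrogen and cyano together at the top, dimethylamino below them, and chloro lowest. Nothing measured here explains why the groups fall in this order.

As far as these compounds go, whether a plain amino group, a methoxy group or a fluoro group on the same carbon would land near dimethylamino, near chloro or at the top level remains open. From the compounds shown here alone, it is also open whether these same groups would keep this order on another carbon of that aromatic ring, since all the changes shown sit at one place.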